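A few compounds are considered here, and "the series" means these few. Any claim that something is new, unique, unknown or untested is made for them only; others in the source may bear on it.

Working notes on the dichloroacetamide-type series, read in a functional assay on BGC-823 cells (Homo sapiens) for antiproliferative activity, read by MTT assay, with a stated time of 72 h; a higher number here means a weaker inhibitor, a lower number a stronger inhibitor. Compound 2 (`O=C(Nc1cccc(C(F)(F)F)c1)C(Cl)Cl`) gives 143000 nM, the only numerical result so far. Compound 3 (`O=C(Nc1ccc(Cl)cc1)C(Cl)Cl`) gives "not determined" (no result reported), so compound 3 has no single number to stand on. Compound 1 (`Cc1ccccc1NC(=O)C(Cl)Cl`) likewise gives "not determined" (no result reported).

The next compound is compound 4 (`O=C(Nc1ccc(SC(F)(F)F)cc1)C(Cl)Cl`), with (trifluoromethyl)sulfanyl in place of chloro on an aromatic carbon, para to a group of 6 heavy atoms: (trifluoromethyl)sulfanyl in place of chloro on an aromatic carbon. The core of compound 3 is otherwise kept.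

Among the compounds with values here, no measured step exists for this series, and without a number for compound 3 the change cannot be sized directly. A small step toward stronger inhibition is expected in this assay, though one that may not clear the usual scatter. The expectation is anchored only on compound 2 at 143000 nM, which places the series at weak inhibition. For compound 4 the estimated value is 100000 nM, with an expected range of 30000 nM to 300000 nM.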

Compound 4, half-maximal inhibitory concentration: 203000 nM
Compound 4: the middle estimate sits 2.0-fold (0.31 log units) below what was measured, and the stated range covers the measured number.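

Within the data shown here, compound 3 has no single number, so no step from it to compound 4 can be read. The compounds shown leave open how (trifluoromethyl)sulfanyl compares with chloro at this place on the shared core. No evidence available here bears on the result.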